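Replacing carboxy on the variable side chain: compound 4

The source may report more compounds than this note shows. Statements on the series, on what has been measured and on what is new or still open speak of the compounds shown alone.

Three members sharing one core have numbers in a functional assay on P388 cells (Mus musculus) for cytotoxicity; a higher number here means a weaker inhibitor, a lower number a stronger inhibitor. Compound 1 `COc1ccc(C[C@H]2C(=O)N[C@@H](C)C(=O)N(C)[C@H]3Cc4ccc(cc4)Oc4cc(ccc4OC)C[C@@H](C(=O)N[C@H](C)C(=O)N[C@@H](CS)C(=O)N2C)N(C)C3=O)cc1`, with sulfanyl on the saturated chain carbon, gives 363 nM. Compound 2 `COc1ccc(C[C@H]2C(=O)N[C@@H](C)C(=O)N(C)[C@H]3Cc4ccc(cc4)Oc4cc(ccc4OC)C[C@@H](C(=O)N[C@H](C)C(=O)N[C@@H](CC=O)C(=O)N2C)N(C)C3=O)cc1`, with formyl there, gives 33.9 nM. Compound 3 `COc1ccc(C[C@H]2C(=O)N[C@@H](C)C(=O)N(C)[C@H]3Cc4ccc(cc4)Oc4cc(ccc4OC)C[C@@H](C(=O)N[C@H](C)C(=O)N[C@@H](CC(=O)O)C(=O)N2C)N(C)C3=O)cc1`, with carboxy there, gives 1200 nM, the highest of the three numbers and so the weakest inhibitor here.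

Compound 4 `COc1ccc(C[C@H]2C(=O)N[C@@H](C)C(=O)N(C)[C@H]3Cc4ccc(cc4)Oc4cc(ccc4OC)C[C@@H](C(=O)N[C@H](C)C(=O)N[C@@H](CCSC)C(=O)N2C)N(C)C3=O)cc1` differs from compound 3 at that same place: (methylsulfanyl)methyl in place of carboxy on a saturated chain carbon bound to a saturated ring carbon. In words, (methylsulfanyl)methyl stands in place of carboxy on a saturated chain carbon bound to a saturated ring carbon.

Going by the values given here, three measured steps bear on this. Carboxy in place of sulfanyl gave a 3.3-fold higher number from compound 1 to compound 3 (0.52 log units; beyond the scatter), and hydroxy in place of hydrogen on a carbonyl carbon gave a 35-fold higher number from compound 2 to compound 3 (1.55 log units; beyond the scatter). Formyl in place of sulfanyl gave an 11-fold lower number from compound 1 to compound 2 (1.03 log units; beyond the scatter), so the two members without carboxy also differ widely. Both sit lower than compound 3, but neither carries the entering group. A modest to large drop is therefore expected in this assay, with compound 1 at 363 nM and compound 2 at 33.9 nM as a rough bracket. The expected change is a 9.2-fold lower number from compound 3 to compound 4 (0.97 log units; beyond the scatter). Compound 4 is estimated at 130 nM, with an expected range of 30 nM to 600 nM.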

Compound 4, half-maximal inhibitory concentration: 20.4 nM
Estimate against measurement, compound 4: 6.4-fold (0.80 log units) above; measured number below the stated range.
By their numbers in this assay, from the lowest: compounds 4 and 2 (each within the scatter of the next); then compound 1; then compound 3.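

Notes on the variable side chain, read in this assay: the step with (methylsulfanyl)methyl in place of carboxy is a 59-fold lower number from compound 3 to compound 4 (1.77 log units; beyond the scatter), and the same group in place of sulfanyl gives an 18-fold lower number from compound 1 to compound 4 (1.25 log units; beyond the scatter), so a low number at this place does not depend on a formyl group. Against formyl, the step is a 1.7-fold lower number from compound 2 to compound 4 (0.22 log units; within the scatter), which lies within the scatter, so formyl and (methylsulfanyl)methyl cannot be ranked here, although they differ in atoms and only formyl has a double bond. Sulfur alone does not set the outcome either, as compound 1 and compound 4 both carry sulfur and yet stand well apart; nothing available accounts for any of these steps.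

The compounds shown do not separate the contribution of the sulfur atom from that of the chain it sits on, a question that a 2-methoxyethyl or a plain propyl chain at this place would address. How far the low numbers extend also stays open, since the series shown holds no amine, no amide and no longer thioether chain here.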